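Swapping the Sulfur-Linked Ring in a Cytotoxicity Series

The compounds below may be only part of what the source reports. "The series", "measured", "known", "first", "only" and "open" are said of these compounds alone.

Compound 1 `Cc1nnc(SCC(=O)N/N=c2/scc(-c3ccc(Cl)cc3)n2-c2ccccc2)s1`: 34.1%
Compound 2 `COc1ccc(-c2cs/c(=N/NC(=O)CSc3nnc(C)s3)n2-c2ccccc2)cc1`: 25.9%

In a functional assay on C6 cells (Rattus norvegicus) for cytotoxicity, read by MTT assay, with a stated time of 24 h, tested at 100 ug/mL (on this read-out lower numbers stand for a stronger effect and higher numbers for a weaker effect at the one concentration tested), compound 1 gives 34.1%. Compound 1 stands alongside compound 2, whose value 25.9% lies within the scatter of it, as the step of a number 8.2 percentage points lower from compound 1 to compound 2 (within the scatter) shows. Compound 3 `O=C(CSc1ncccn1)N/N=c1/scc(-c2ccc(Cl)cc2)n1-c1ccccc1` differs from compound 1 by pyrimidin-2-yl in place of 5-methyl-1,3,4-thiadiazol-2-yl on a sulfur. Among the measured compounds shown here, the one measured step concerns a different place in the molecule, so no measured step bears on this change. A step no larger than the scatter is therefore expected, a number 0.1 percentage points lower from compound 1 to compound 3 (within the scatter). Compound 3 is estimated at 34%, in a range from 15% to 55%.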

Compound 3, a percentage reported as activity, at one concentration (the size of the read-out at that concentration, not a potency): 45.5%
Estimate against measurement, compound 3: 11.5 percentage points below; low and high end bracket the measured number.
By their numbers in this assay, from the lowest: compounds 2 and 1 (each within the scatter of the next); then compound 3.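

On the sulfur, the ring matters: in this assay, pyrimidin-2-yl in place of 5-methyl-1,3,4-thiadiazol-2-yl gives a number 11.4 percentage points higher from compound 1 to compound 3 (beyond the scatter). This is a modestly weaker effect at the one concentration tested, and it is the only step shown at this position. Nothing available accounts for the difference.

Open, from the compounds shown here alone, is how a plain phenyl ring or a simple methyl group on this sulfur would compare. Also open, going by these compounds, is whether pyrimidin-2-yl would give a similar step alongside the methoxy group of compound 2.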